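Heteroaryl carbonyl in place of cyclobutylsulfanyl on the piperidine amide

The compounds below may be only part of what the source reports. "The series", "measured", "known", "first", "only" and "open" are said of these compounds alone.

Compound 2 `Cc1nc(S(C)(=O)=O)ccc1Oc1ncnc(OC2CCN(C(=O)SC3CCC3)CC2)c1F` gives 77.4 nM in a functional assay on isolated protein for inhibition of Glucose-dependent insulinotropic receptor (Rattus norvegicus), read by HTRF and cAMP accumulation; a lower number here means that less compound is needed, a higher number that more compound is needed for the effect. Compound 1 `Cc1nc(S(C)(=O)=O)ccc1Oc1ncnc(OC2CCN(C(=O)SC(C)C)CC2)c1F` gives 41.3 nM in this assay. The step of a 1.9-fold higher number from compound 1 to compound 2 (0.27 log units; within the scatter) leaves the two numbers within the scatter of each other, so no order between them can be claimed. Compound 3 `Cc1nc(S(C)(=O)=O)ccc1Oc1ncnc(OC2CCN(C(=O)c3noc(C(C)(C)F)n3)CC2)c1F` differs from compound 2 in that (a group of 9 heavy atoms (5 carbon, 2 nitrogen, 1 oxygen, 1 fluorine; one five-membered aromatic ring with 3 hetero atoms) in place of a group of 5 heavy atoms (4 carbon, 1 sulfur; one four-membered non-aromatic ring of carbon only), on a carbonyl carbon). For the measured compounds named here, no measured step bears on this change directly: the single known step, a 1.9-fold higher number from compound 1 to compound 2 (0.27 log units; within the scatter), swaps one alkyl on the sulfur for another and says nothing about removing the sulfur altogether. No movement beyond the scatter is therefore expected, with wide uncertainty. Compound 3 is estimated at 60 nM (range 12 nM to 300 nM). The expected step is a 1.3-fold lower number from compound 2 to compound 3 (0.11 log units; within the scatter).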

Compound 3, half-maximal effective concentration: 103 nM
Compound 3: the middle estimate sits 1.7-fold (0.23 log units) below what was measured; the range from low to high includes it.
By their numbers in this assay, from the lowest: compounds 1, 2 and 3 (each within the scatter of the next, the first and the last beyond it).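

In this assay, the group on the carbonyl carbon need not hold sulfur: the five-membered aromatic ring with 3 hetero atoms replaces cyclobutylsulfanyl with a 1.3-fold higher number from compound 2 to compound 3 (0.12 log units; within the scatter). Measured against the isopropyl group on sulfur, the same ring gives a 2.5-fold higher number from compound 1 to compound 3 (0.40 log units; beyond the scatter), so the replacement is tolerated relative to one sulfur-linked group but not fully relative to the other. No supporting data on the compounds explain these steps. Still open, going by these compounds, are the contribution of the fluorine in the entering group and how an amine or an alkoxy group on the same carbonyl carbon would read.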